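Adding a nitro group to a potent compound

The compounds below may be only part of what the source reports. "The series", "measured", "known", "first", "only" and "open" are said of these compounds alone.

Measured so far in a functional assay on MCF7 cells (Homo sapiens) for cytotoxicity, read by MTT assay, with a stated time of 48 h; on this read-out lower numbers stand for stronger inhibition and higher numbers for weaker inhibition:
Compound 1 `C/C(=N/NC(=S)Nc1cccc([N+](=O)[O-])c1)c1ccccn1` gives 38 nM
Compound 2 `C/C(=N\NC(=S)Nc1ccccc1)c1ccccn1` gives 0.18 nM

Compound 2 holds the lower of the two numbers, and the gap to compound 1 lies well beyond the usual scatter. Compound 3 `C/C(=N\NC(=S)Nc1cccc([N+](=O)[O-])c1)c1ccccn1` differs from compound 2 at one place: nitro in place of hydrogen on an aromatic carbon. Among the measured compounds shown here, no measured pair shows this change alone, so the forecast is uncertain. A clear rise in this assay, beyond the scatter, is expected since compound 1 with its nitro gives 38 nM. The expected size is a 44-fold higher number from compound 2 to compound 3 (1.65 log units; beyond the scatter). For compound 3 the estimated value is 8 nM, with an expected range from 0.8 nM to 60 nM.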

Compound 3, half-maximal inhibitory concentration: 38 nM
Beside the measured number, compound 3's estimate is 4.8-fold (0.68 log units) below it; low and high end bracket the measured number.
By their numbers in this assay, from the lowest: compound 2; then compounds 1 and 3 (each within the scatter of the next).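

In this assay, nitro in place of hydrogen on an aromatic carbon, meta to a large group, gives a 210-fold higher number from compound 2 to compound 3 (2.32 log units; beyond the scatter). Among the compounds shown here, this is the first pair that shows this change alone, and the step is large. The two nitro compounds show no change at the digits printed from compound 1 to compound 3 (within the scatter), so the drawn configuration of the double bond makes no visible difference here, and what sets this pair apart is worth stating exactly: the fact that compounds 1 and 3 differ only in the configuration as drawn

As far as these compounds go, whether an amine or a methoxy group at this place would raise the number as far remains open. So does whether nitro would act the same way elsewhere on that aromatic ring.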